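A Chlorine Added to Compound 1

This account rests on a few compounds, and the source may have more. Where it says the series, first, only, none or still open, it means among the compounds named here.

Of the compounds shown here, three that share one core have been tested in an assay on isolated protein for binding affinity to 5-hydroxytryptamine receptor 1B (Rattus norvegicus); on this read-out higher numbers stand for weaker inhibition and lower numbers for stronger inhibition. Compound 1 `c1ccc2c(c1)CC2CN1CCN(c2cccc3c2OCCO3)CC1` gives 214 nM. Compound 2 `c1ccc2c(c1)CCC2CCCN1CCN(c2cccc3c2OCCO3)CC1` gives 204 nM, and compound 3 `C1=C(CCN2CCN(c3cccc4c3OCCO4)CC2)c2ccccc2C1` gives 251 nM. Compound 1 stands second highest of the three numbers; its nearest neighbour, compound 2, lies within the scatter of it, and even the furthest, compound 3, lies within the scatter as well. The three numbers cannot be told apart.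

Compound 4 `Clc1cccc2c1CC2CN1CCN(c2cccc3c2OCCO3)CC1` has not yet been measured. Compared with compound 1 it carries chloro in place of hydrogen on an aromatic carbon. Among the measured compounds shown here, no two measured compounds differ in this one place, so the measured set gives no direct guide to what such a change does. With nothing pointing one way or the other, the step of a 1.1-fold lower number from compound 1 to compound 4 (0.03 log units; within the scatter) is expected to be small, not beyond the scatter, in either direction. Compound 4 is therefore estimated at 200 nM, with a range from 80 nM to 500 nM.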

Compound 4, inhibition constant: 550 nM
Compound 4: middle estimate off by 2.8-fold (0.44 log units), on the low side; the whole stated range lies below it.
By their numbers in this assay, from the lowest: compounds 2, 1 and 3 (each within the scatter of the next); then compound 4.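

In this assay, chloro in place of hydrogen on this aromatic carbon gives a 2.6-fold higher number from compound 1 to compound 4 (0.41 log units; beyond the scatter). This shows that the position is not indifferent to substitution: a single chlorine atom on the six-membered aromatic ring is enough to weaken inhibition modestly, and the change reaches beyond the usual scatter of the assay. Nothing measured here bears on why the number moves in this direction.

This is one pair of compounds and one substituent, so it sets no general rule for the position. Going by these compounds, whether a fluoro, methyl or methoxy group on the same carbon would also give a higher number remains open, as does the effect of chloro on the other aromatic carbons of that ring.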